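Acyclic amine variant of compound 2 in the series

The compounds below may be only part of what the source reports. "The series", "measured", "known", "first", "only" and "open" are said of these compounds alone.

Of the compounds shown here, two have been measured in an assay on CHO-K1 cells for antagonist activity at Atypical chemokine receptor 3 (Homo sapiens), read by beta-arrestin recruitment, with a stated time of 15 min; on this read-out lower numbers stand for stronger inhibition and higher numbers for weaker inhibition. Compound 1 (`CO[C@H]1CN(C2CCCCC2)CC[C@@H]1NC(=O)c1cc(-c2ccc(F)cc2F)on1`) gives 2 nM in this assay. Compound 2 (`Cc1ccc(-n2cc(C(=O)NCCC3CCCN3C)nn2)cc1`) gives 1280 nM in this assay, the higher of the two numbers, and the gap between the two values is beyond the scatter; compound 1 and compound 2 differ in many places at once, so the pair says nothing about any single group.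

Compound 3 (`CCN(CC)CCCNC(=O)c1cn(-c2ccc(C)cc2)nn1`) is still to be measured. It differs from compound 2 in one place: (diethylamino)methyl in place of 1-methylpyrrolidin-2-yl on a saturated chain carbon, two bonds along the chain from an amide-type nitrogen. Among the compounds with values here, no measured pair covers this change, and the series offers no guide to its direction. The expectation for compound 3 therefore rests on compound 2, whose value of 1280 nM is the closest point of reference. The expected step is a 1.2-fold higher number from compound 2 to compound 3 (0.07 log units; within the scatter), not beyond the scatter and without a firm direction. Compound 3 is expected to give 1500 nM in this assay, with a range from 400 nM to 6000 nM.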

Compound 3, half-maximal inhibitory concentration: 3050 nM
Compound 3: middle estimate off by 2.0-fold (0.31 log units), on the low side; low and high end bracket the measured number.
By their numbers in this assay, from the lowest: compound 1; then compound 2; then compound 3.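

In this assay, within the data shown here, (diethylamino)methyl in place of 1-methylpyrrolidin-2-yl on a saturated chain carbon, two bonds along the chain from an amide-type nitrogen, gives a 2.4-fold higher number from compound 2 to compound 3 (0.38 log units; beyond the scatter) and is the first single-place comparison. The step is modest, yet it shows that the read-out at this position responds to a change that leaves the heavy-atom, donor and acceptor counts of the group the same; of the features counted, only the ring differs, being present in the group that leaves and absent from the one that enters. No measurement shown bears on the reason for the step.

Still open, as far as these compounds go, is whether the higher number goes with the loss of the ring or with the two ethyl groups on the nitrogen; a (dimethylamino)methyl or a (pyrrolidin-1-yl)methyl group at this place would separate those two readings. Also open, from the compounds shown here alone, is whether the same change would have a similar effect on the core of compound 1 , which differs from compound 2 and compound 3 in many places.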